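Benzamido in Place of Pyrrolidinyl on a Purine Core

The source may hold more compounds than are shown below. What is called first, only, known or untested is meant among the compounds shown, and "the series" means these compounds.

Of the compounds shown here, three sharing one core have been measured in an assay on HEK293 cells for antagonist activity at Toll-like receptor 9 (Homo sapiens), read by spectrophotometry; on this read-out higher numbers stand for weaker inhibition and lower numbers for stronger inhibition. Compound 1 `CCN1CCN(CCCn2cnc3c(N4CCN(CC)CC4)nc(N4CCCC4)nc32)CC1` gives 500 nM, the highest number of the three, beyond the scatter from both others. Compound 2 `CCN1CCN(c2nc(NCc3ccc(F)cc3)nc3c2ncn3CCCN2CCCC2)CC1` gives 40 nM, the furthest from compound 1, and compound 3 `CCN1CCN(c2nc(NCc3ccc(CN(C)C)cc3)nc3c2ncn3CCCN2CCCC2)CC1` gives 90 nM, the nearest to compound 1. Compounds 2 and 3 differ from one another only in the group on the benzyl ring, and that change gave a 2.3-fold higher number from compound 2 to compound 3 (0.35 log units; beyond the scatter).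

Compound 4 `CCN1CCN(CCCn2cnc3c(N4CCN(CC)CC4)nc(NC(=O)c4ccccc4)nc32)CC1` is reached from compound 1 by one change: benzamido in place of pyrrolidin-1-yl on an aromatic carbon. Among the measured compounds shown here, no measured pair shows this exact change. Compounds 2 and 3 carry a benzyl-bearing amine at the same position and give lower numbers than compound 1, but each also differs from compound 1 in the chain on the imidazole nitrogen, so their gap to compound 1 cannot be read as a single step. The step from compound 2 to compound 3 concerns only a substituent on the benzyl ring and bears only loosely on an amide.

On this basis compound 4 is expected to give 250 nM, within a range of 60 nM to 1000 nM, which is an estimated step of a 2.0-fold lower number from compound 1 to compound 4 (0.30 log units; within the scatter) in this assay .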

Compound 4, half-maximal inhibitory concentration: 340 nM
For compound 4 the middle estimate is 1.4-fold (0.13 log units) below the measured one; measured number inside the range.
By their numbers in this assay, from the lowest: compound 2; then compound 3; then compounds 4 and 1 (each within the scatter of the next).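

In this assay, placing benzamido where pyrrolidin-1-yl stood, on the aromatic carbon between two ring nitrogen atoms, gives a 1.5-fold lower number from compound 1 to compound 4 (0.17 log units; within the scatter), so on the core of compound 1 the two groups cannot be told apart by this read-out. Among the compounds shown here, this is the first direct reading at this position with everything else held fixed: benzamido brings a six-membered aromatic ring, a double bond outside aromatic rings and a hydrogen-bond donor, none of which pyrrolidin-1-yl carries, and the number still stays within the scatter. The compounds shown offer no measured basis for explaining this tolerance, and nothing is available that would tie the result to any property of either group.

What the compounds leave open is whether this position stays as undemanding with a benzylamino group or a plain primary amine on the core of compound 1, which would separate the effect of the amide carbonyl from that of the aromatic ring. From the compounds shown here alone, it also remains open whether a fluoro or a (dimethylamino)methyl group on the ring of benzamido would move the number beyond the scatter.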